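Proline-to-serine swap on the free acid of the series

The source may report more compounds than this note shows. Statements on the series, on what has been measured and on what is new or still open speak of the compounds shown alone.

Measured compounds in a functional assay on the whole organism (Tail, strain ICR) with Mus musculus as the target, in the tail flick test, with a stated time of 150 min, at a dose of 25 umol/kg by the oral route; a higher number here means a stronger effect of the compound at the dose given, a lower number a weaker effect:
compound 1 `O=C(O)[C@@H]1CCCN1C(=O)CN(c1nc(Cl)nc2[nH]cnc12)C1CC1` gives 7.29%
compound 2 `O=C(OCc1ccccc1)[C@@H]1CCCN1C(=O)CN(c1nc(Cl)nc2[nH]cnc12)C1CC1` gives 31.1%
compound 3 `C[C@@H](O)[C@H](NC(=O)CN(c1nc(Cl)nc2[nH]cnc12)C1CC1)C(=O)OCc1ccccc1` gives 12.8%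

Compound 1 stands lowest of the three numbers; compound 3 lies within the scatter of it, and only compound 2 lies beyond the scatter above it. For the measured compounds named here, the one step measured, a number 23.8 percentage points higher from compound 1 to compound 2 (beyond the scatter), concerns benzyl in place of hydrogen on an oxygen next to a carbonyl group and does not touch the change now considered.

Compound 4 `O=C(CN(c1nc(Cl)nc2[nH]cnc12)C1CC1)N[C@@H](CO)C(=O)O` differs from compound 1 by (1-carboxy-2-hydroxyethyl)amino in place of 2-carboxypyrrolidin-1-yl on a carbonyl carbon. Going by the values given here, no measured step bears on this change. Among the compounds with values here, compounds 2 and 3 both carry the benzyl ester and show the lower number for the open-chain amino acid, though no step between them is computed. For compound 4 the expectation in this assay is therefore a step of a number 1.3 percentage points lower from compound 1 to compound 4 (within the scatter), no change beyond the scatter, giving an estimate of 6% within 0% to 18%.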

Compound 4, a percentage reported as activity, at one dose (the size of the read-out at that dose, not a potency): 18.8%
Compound 4: middle estimate off by 12.8 percentage points, on the low side; the measured number lies above the stated range.
By their numbers in this assay, from the lowest: compounds 1, 3 and 4 (each within the scatter of the next, the first and the last beyond it); then compound 2.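

In this assay, the open-chain (1-carboxy-2-hydroxyethyl)amino group on a carbonyl carbon gives a number 11.5 percentage points higher from compound 1 to compound 4 (beyond the scatter), so on the free acid the 2-carboxypyrrolidin-1-yl ring is not required for the read-out at this dose. Among the benzyl esters, compound 3 gives 12.8% and compound 2 gives 31.1%, an order that does not carry over to this free-acid pair, though compound 3 has a different open chain. Nothing available explains the step.

From the compounds shown here alone, it remains open whether the gain comes from the hydroxyl or from the ring opening; a plain methyl or a longer chain at that place would separate the two. The benzyl ester of compound 4 is also an open case.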